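A few compounds are considered here, and "the series" means these few. Any claim that something is new, unique, unknown or untested is made for them only; others in the source may bear on it.

Measured in a functional assay on HOS cells (Homo sapiens) for antiproliferative activity, with a stated time of 72 h; on this read-out lower numbers stand for stronger inhibition and higher numbers for weaker inhibition:
- Compound 1 `OC[C@H]1O[C@@H](n2cnc3c(NCc4ccc(F)cc4)ncnc32)[C@H](O)[C@@H]1O`: 13200 nM
- Compound 2 `OC[C@H]1O[C@@H](n2cnc3c(NCc4ccc(Br)cc4)ncnc32)[C@H](O)[C@@H]1O`: > 166000 nM

Compound 2 has no exact number, and its > 166000 nM is a limit of the assay. Compound 3 `OC[C@H]1O[C@@H](n2cnc3c(NCc4ccc(OC(F)(F)F)cc4)ncnc32)[C@H](O)[C@@H]1O` keeps the shared core and carries trifluoromethoxy in place of bromo on an aromatic carbon, para to a large group (trifluoromethoxy in place of bromo on an aromatic carbon).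

Among the measured compounds shown here, only one measured step bears on this change, and it concerns the same aromatic carbon. That step is an at least 12-fold higher number from compound 1 to compound 2 (1.09 log units; beyond the scatter), with bromo in place of fluoro. It shows that swapping this single group can matter greatly in this assay, but two compounds give no trend, and neither carries trifluoromethoxy. A lower number than the limit of compound 2 is therefore expected, though compound 3 may well reach the same limit. The large size of an at least 12-fold higher number from compound 1 to compound 2 (1.09 log units; beyond the scatter) suggests a wide range, lying mostly between the two measured compounds. The expected change is an at least 2.3-fold lower number from compound 2 to compound 3 (0.37 log units; beyond the scatter). For compound 3 the estimate is 70000 nM, with an expected range from 15000 nM to 166000 nM.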

Compound 3, half-maximal inhibitory concentration: > 166000 nM
Compound 3: no number, only a limit (the forecaster's own chance of this, stated with the estimate: 45%); at least 2.3-fold (0.37 log units) between middle value and limit.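

In this assay, compound 3 falls on the same side as compound 2, so trifluoromethoxy at this aromatic carbon gives no more readable activity than bromo does, and there is an at least 12-fold higher number from compound 1 to compound 3 (1.09 log units; beyond the scatter). With two different groups now set against fluoro, the gap no longer rests on a single replacement: among the three compounds shown, only the fluoro compound, compound 1, gives an exact number, so the position looks sensitive to what is placed there rather than tolerant of a range of groups. The step from compound 2 to compound 3 cannot be read, and no order can be given for bromo and trifluoromethoxy, because of what the assay can report: the limit of > 166000 nM in this assay, at which 2 of the 3 values shown sit.

Going by these compounds, what stays open is whether fluoro is unusual at this aromatic carbon or whether the activity simply falls away with most other groups, a question that a plain hydrogen, a chloro or an amine in the same place would help to answer. On these data alone, how much weaker compound 2 and compound 3 really are than compound 1 also remains unknown.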